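A Phenyl Added to the Furan of a Cyanoacrylamide

A few compounds are considered here, and "the series" means these few. Any claim that something is new, unique, unknown or untested is made for them only; others in the source may bear on it.

Three related compounds have been tested in a functional assay on SW480 cells (Homo sapiens) for inhibition, read by MTT assay, with a stated time of 72 h; a lower number here means a stronger inhibitor of growth, a higher number a weaker inhibitor of growth. Compound 1 `N#C/C(=C\c1ccc([N+](=O)[O-])cc1)C(=O)c1c[nH]c2ccccc12` gives 42000 nM. Compound 2 `N#C/C(=C\c1ccc[nH]1)C(=O)NCc1ccc(Cl)c(Cl)c1` gives > 50000 nM, which is a limit of the assay rather than a number, matching (the limit of > 50000 nM in this assay, at which 1 of the 3 values shown sits). Compound 3 `COc1ccc(CNC(=O)/C(C#N)=C/c2ccco2)cc1` gives 31000 nM. The numbers of compound 3 and compound 1 lie within the usual scatter of each other, so the two cannot be told apart on this evidence. Compound 4 `COc1ccc(CNC(=O)/C(C#N)=C/c2ccc(-c3ccccc3)o2)cc1` carries phenyl in place of hydrogen on an aromatic carbon, with the rest of the shared core unchanged. For the measured compounds named here, no measured pair shows what this change does. A modest shift is expected, in either direction or none beyond the scatter. Compound 4 is estimated at 15000 nM, with a range from 4000 nM to 50000 nM. That estimate means an expected step of a 2.1-fold lower number from compound 3 to compound 4 (0.32 log units; beyond the scatter).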

Compound 4, concentration for 50% growth inhibition: > 100000 nM
Compound 4 was reported as a limit; the forecaster's own chance of this, stated with the estimate: 25%; middle value at least 6.6-fold (0.82 log units) away from the limit.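

In this assay, phenyl in place of hydrogen on an aromatic carbon, next to the ring oxygen, gives an at least 3.2-fold higher number from compound 3 to compound 4 (0.50 log units; beyond the scatter), so this change weakens growth inhibition rather than strengthening it. Compound 4 gives > 100000 nM, which is a limit of the assay and not a number: the limit of > 100000 nM in this assay, at which 1 of the 4 values shown sits.

As far as these compounds go, the true size of the step therefore stays unknown, and this single pair shows only that phenyl does not help here. From the compounds shown here alone, whether an amine or a carboxylic acid at this carbon would fare better remains open, as does whether phenyl has the same effect on another core.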